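This account rests on a few compounds, and the source may have more. Where it says the series, first, only, none or still open, it means among the compounds named here.

Compound 3 `c1cn2cc(-c3ccsc3)nc(-c3ccc4ncn(C5CCCCC5)c4c3)c2n1` stands second highest of the three numbers recorded in a functional assay on OVCAR-8 cells (Homo sapiens) for inhibition, read by sulforhodamine B assay, with a stated time of 48 h, tested at 10 uM; a lower number here means less inhibition, a higher number more inhibition at the concentration tested (going by the name of the read-out): compound 3 gives 12.1%. Its nearest neighbour is compound 1 `Brc1cn2ccnc2c(-c2ccc3ncn(C4CCCCC4)c3c2)n1`, which gives 4.92% in this assay, a pair that is within the scatter of each other. The furthest is compound 2 `O=Cc1ccc(-c2cn3ccnc3c(-c3ccc4ncn(C5CCCCC5)c4c3)n2)cc1`, which gives 44% in this assay, a gap that is beyond the scatter.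

Compound 4 `c1csc(-c2cn3ccnc3c(-c3ccc4ncn(C5CCCCC5)c4c3)n2)c1` differs from compound 3 only in how the same atoms are joined: thiophen-2-yl in place of thiophen-3-yl on an aromatic carbon.

For the measured compounds named here, no measured step swaps one thiophene isomer for the other, so the bearing of the earlier steps is indirect. The step of a number 7.2 percentage points higher from compound 1 to compound 3 (within the scatter) shows that placing thiophen-3-yl where bromo sat stayed within the scatter, while the step of a number 31.9 percentage points lower from compound 2 to compound 3 (beyond the scatter) shows that thiophen-3-yl in place of 4-formylphenyl fell well beyond it. With the ring kept and only its point of attachment moved, he expects no step beyond the scatter in this assay. His estimate for compound 4 is 12%, with a range from 2% to 25%, meaning an expected step of a number 0.1 percentage points lower from compound 3 to compound 4 (within the scatter).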

Compound 4, a percentage reported as inhibition, at one concentration (the size of the read-out at that concentration, not a potency): 9.34%
Beside the measured number, compound 4's estimate is 2.7 percentage points above it; measured number inside the range.
By their numbers in this assay, from the lowest: compounds 1, 4 and 3 (each within the scatter of the next); then compound 2.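

For the compounds shown here, the step of a number 2.8 percentage points lower from compound 3 to compound 4 (within the scatter) in this assay shows for the first time that moving only the point of attachment of the thiophene on this aromatic carbon leaves the number within the scatter. The step of a number 4.4 percentage points higher from compound 1 to compound 4 (within the scatter) places thiophen-2-yl, like thiophen-3-yl, within the scatter of bromo, while the step of a number 34.7 percentage points lower from compound 2 to compound 4 (beyond the scatter) shows that both thiophene isomers now stand apart from 4-formylphenyl, the only group shown that lifts the number beyond that scatter. Nothing measured here accounts for the gap between 4-formylphenyl and the two thiophenes.

Still open, going by these compounds, is whether that lift belongs to the formyl group or to the phenyl ring itself. An unsubstituted phenyl, or a phenyl carrying a carboxylic acid or an amine instead of the formyl group, would separate the two.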